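A Glycol Ether Chain Replaces the Trifluoromethyl Terminus

A few compounds are considered here, and "the series" means these few. Any claim that something is new, unique, unknown or untested is made for them only; others in the source may bear on it.

Compound 1 `Nc1ccc2cccc(OCCC(F)(F)F)c2n1` gives 722 nM in an assay on cells with melanin-concentrating hormone receptor 1 (Homo sapiens) as the target, read by radioligand binding; on this read-out higher numbers stand for weaker inhibition and lower numbers for stronger inhibition. For the measured compounds named here, it stands highest of the two numbers measured so far; the nearest is compound 2 `CC(C)Oc1cccc2ccc(N)nc12`, which in this assay gives 437 nM, and the step of a 1.7-fold lower number from compound 1 to compound 2 (0.22 log units; within the scatter) lies within the scatter. Compound 3 `COCCOCCOc1cccc2ccc(N)nc12` has not yet been measured. Its difference from compound 1 is 2-methoxyethoxy in place of trifluoromethyl on a saturated chain carbon, two bonds along the chain from an oxygen on an aromatic ring. Going by the values given here, the only measured step that bears on this change is the one from compound 1 to compound 2, where the chain on the aromatic oxygen was altered without any shift beyond the scatter. Among the compounds with values here, on that basis no step beyond the scatter is expected in this assay for the present change either, although the entering 2-methoxyethoxy group has no direct precedent among the measured compounds. For compound 3 the expected value is 700 nM, with a range from 250 nM to 2000 nM, which means an expected step of a 1.0-fold lower number from compound 1 to compound 3 (0.01 log units; within the scatter).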

Compound 3, half-maximal inhibitory concentration: > 2000 nM
Compound 3: no number, only a limit; the forecaster's own chance of this, stated with the estimate: 5%; middle value at least 2.8-fold (0.45 log units) from the limit.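

In this assay compound 3 gives > 2000 nM, which is a limit of the assay and not a number. Putting 2-methoxyethoxy in place of trifluoromethyl at this place on the chain brings an at least 2.7-fold higher number from compound 1 to compound 3 (0.44 log units; beyond the scatter), so the chain on the aromatic oxygen is not indifferent to what it carries, which the earlier step, a 1.7-fold lower number from compound 1 to compound 2 (0.22 log units; within the scatter), did not show. The size of this change therefore rests on a limit alone: the limit of > 2000 nM in this assay, at which 1 of the 3 values shown sits.

The compounds shown leave open whether the step goes with the greater length of the chain or with its two ether oxygens, and how far past its limit compound 3 lies. A plain longer alkyl chain, or a chain ending in an amine, would bear on the first of these questions.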